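Propyl to isopropyl: same atoms, joined differently

A few compounds are considered here, and "the series" means these few. Any claim that something is new, unique, unknown or untested is made for them only; others in the source may bear on it.

compound 1 `CCOC(=O)NC1=NC(c2ccccc2)CN1C` gives 78 mg/kg
compound 2 `COC(=O)NC1=NC(c2ccccc2F)CN1C` gives 74 mg/kg
compound 3 `CCCOC(=O)NC1=NC(c2ccccc2F)CN1C` gives 23 mg/kg

In a functional assay on the whole organism for antagonist activity, with Mus musculus as the target, in the maximal electroshock model (a higher number here means that more compound is needed for the effect, a lower number that less compound is needed), compound 3 has the lowest number of the three, so it needs the least compound for the effect. Compound 1 and compound 2 both stand above it by more than the scatter of repeated measurements.

The next structure is compound 4 `CC(C)OC(=O)NC1=NC(c2ccccc2F)CN1C`, which differs from compound 3 by a single change (isopropyl in place of propyl on an oxygen next to a carbonyl group): isopropyl in place of propyl on an oxygen next to a carbonyl group. The two have the same atoms, joined differently.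

Going by the values given here, only one measured step bears on this place. It is a 3.2-fold lower number from compound 2 to compound 3 (0.51 log units; beyond the scatter) and it was modest in size. That step lengthened the chain, whereas the new change keeps the same atoms. Among the compounds with values here, no measured compound carries isopropyl here, so the data give no firm direction for this swap. The expected result is therefore a small upward drift that stays within the scatter (a 1.3-fold higher number from compound 3 to compound 4 (0.12 log units; within the scatter)). For compound 4 the estimated value is 30 mg/kg (expected range 12 mg/kg to 70 mg/kg).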

Compound 4, dose for half-maximal effect: 23 mg/kg
The estimate for compound 4 lay 1.3-fold (0.12 log units) above the measured number, within the range that was stated.
By their numbers in this assay, from the lowest: compounds 3 and 4 (each within the scatter of the next); then compounds 2 and 1 (each within the scatter of the next).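

In this assay, joining the same atoms as a branched chain rather than a straight chain gives no change at the digits printed from compound 3 to compound 4 (within the scatter), so at this position the branched chain and the straight chain cannot be told apart. Set beside the earlier 3.2-fold lower number from compound 2 to compound 3 (0.51 log units; beyond the scatter), the new 3.2-fold lower number from compound 2 to compound 4 (0.51 log units; beyond the scatter) shows that the drop in dose seen on going from methyl to propyl also appears with isopropyl, so among the compounds shown it does not depend on one particular way of joining these atoms. Nothing measured alongside these compounds speaks to the reason for this result.

Going by these compounds, it remains open whether a longer chain such as butyl, or a more heavily branched one such as tert-butyl, on the same oxygen would lower the number further, leave it flat or raise it. The effect of the fluorine also stays unsettled, as compound 1 differs from each of the other compounds in more than one place, and a ring such as cyclopropyl on this oxygen is another open case.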